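The source may report more compounds than this note shows. Statements on the series, on what has been measured and on what is new or still open speak of the compounds shown alone.

Measured so far in a functional assay on MDA-MB-231 cells (Homo sapiens) for cytotoxicity, read by sulforhodamine B assay, with a stated time of 72 h; on this read-out lower numbers stand for stronger inhibition of growth and higher numbers for weaker inhibition of growth:
- compound 1, `CCCCCCCCC(=O)N1c2ccccc2CCC1C(=O)Nc1ccccc1C(F)(F)F`, gives 3350 nM
- compound 2, `CCC(=O)N1c2ccccc2CCC1C(=O)Nc1ccccc1C(F)(F)F`, gives only a limit of the assay, > 80000 nM
- compound 3, `CCCCCCCCC(=O)N1c2ccccc2CCC1C(=O)Nc1cc(C(F)(F)F)cc(C(F)(F)F)c1`, gives 7530 nM

Compound 1 and compound 2 share one core and differ by a single change: hydrogen in place of hexyl on a saturated chain carbon, two bonds along the chain from a carbonyl carbon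

That change moved the read-out by an at least 23-fold higher number from compound 1 to compound 2 (1.37 log units; beyond the scatter). The step is open at its upper end, since compound 2 sits at the limit of > 80000 nM in this assay, at which 1 of the 3 values shown sits.

Compound 3 carries the same chain as compound 1 on a different core. How the core of compound 3 differs from the core of compound 1 is not broken down here; the two values show compound 3 at a higher number than compound 1, beyond the scatter.

Compound 4, `CCC(=O)N1c2ccccc2CCC1C(=O)Nc1cc(C(F)(F)F)cc(C(F)(F)F)c1`, is not yet measured. It stands to compound 3 as compound 2 stands to compound 1: hydrogen in place of hexyl on a saturated chain carbon, two bonds along the chain from a carbonyl carbon

The place of the change is the same, word for word, in both pairs, so this is the same change. For compound 4 in this assay the expected step is therefore of the same kind and size as the one already in hand, a 23-fold higher number from compound 3 to compound 4 (1.35 log units; beyond the scatter), resting on compound 1 to compound 2 having shifted by an at least 23-fold higher number from compound 1 to compound 2 (1.37 log units; beyond the scatter) and on compound 3 already starting from 7530 nM. Compound 4 is estimated at 170000 nM, within 40000 nM to 600000 nM, and most likely the assay will report only a limit.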

Compound 4, concentration for 50% growth inhibition: 7280 nM
The estimate for compound 4 lay 23-fold (1.37 log units) above the measured number; measured number below the stated range.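

In this assay, hydrogen in place of hexyl on the core of compound 3 gives a 1.0-fold lower number from compound 3 to compound 4 (0.01 log units; within the scatter), whereas the same change on the core of compound 1 gives an at least 23-fold higher number from compound 1 to compound 2 (1.37 log units; beyond the scatter), so the effect of this change does not carry from one core to the other: the same change on two cores in this assay, an at least 23-fold higher number (1.37 log units; beyond the scatter) from compound 1 to compound 2 and a 1.0-fold lower number (0.01 log units; within the scatter) from compound 3 to compound 4, at least 24-fold (1.39 log units) apart, beyond the scatter of two such steps

This shows that the result for the propanoyl compound on the core of compound 1 cannot serve as a rule for the series, and that on the core of compound 3 the two chains give values within the scatter of each other. It does not show which part of the difference between the two cores is responsible, and one pair on each core cannot establish a trend for the wider series. The step on the core of compound 1 also ends at a limit of the assay rather than at a number, so its full size remains unknown: the limit of > 80000 nM in this assay, at which 1 of the 4 values shown sits.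

The compounds shown leave open how chains of intermediate length, or a longer chain, would behave on either core. Also open, from the compounds shown here alone, is whether an amine or a carboxylic acid at the end of the chain would follow the pattern of either core.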